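A Single Bromine Added to an Antiproliferative Sulfonamide

The source may hold more compounds than are shown below. What is called first, only, known or untested is meant among the compounds shown, and "the series" means these compounds.

Of the compounds shown here, three built on one shared core have been tested in a functional assay on MCF7 cells (Homo sapiens) for antiproliferative activity, read by sulforhodamine B assay, with a stated time of 48 h; on this read-out higher numbers stand for weaker inhibition and lower numbers for stronger inhibition. Compound 1 `O=C1NCCN1c1ccc(S(=O)(=O)Nc2ccc3[nH]ccc3c2)cc1` gives 170 nM. Compound 2 `O=C1NCCN1c1ccc(S(=O)(=O)Nc2ccccc2)cc1` gives 470 nM. Compound 3 `COc1ccc(NS(=O)(=O)c2ccc(N3CCNC3=O)cc2)cc1OC` gives 610 nM.

Among these three numbers, compound 2 holds the second highest. Its nearest neighbour is compound 3, whose number lies within the usual scatter of repeated measurements, so the two cannot be told apart on potency. Compound 1 is the furthest away, with a lower number that lies beyond the scatter, which makes compound 1 the stronger inhibitor of that pair.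

Compound 4 `O=C1NCCN1c1ccc(S(=O)(=O)Nc2ccc(Br)cc2)cc1` has not yet been measured. It differs from compound 2 in one place: bromo in place of hydrogen on an aromatic carbon. Going by the values given here, no pair of measured compounds differs by exactly this kind of change, so there is no directly comparable step to rest on. The change adds one heavy atom and no ring, and compound 3, with its value of 610 nM, shows that a change on the same ring of compound 2 need not move the number beyond the scatter.

The step from compound 2 to compound 4 is expected to be a 1.5-fold lower number from compound 2 to compound 4 (0.17 log units; within the scatter), a slight move toward a lower number that may well stay within the scatter. Compound 4 is therefore estimated at 320 nM, with a range from 120 nM to 850 nM.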

Compound 4, half-maximal inhibitory concentration: 240 nM
Beside the measured number, compound 4's estimate is 1.3-fold (0.12 log units) above it; measured number inside the range.
By their numbers in this assay, from the lowest: compounds 1, 4, 2 and 3 (each within the scatter of the next, the first and the last beyond it).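

In this assay, putting bromo in place of hydrogen gives a 2.0-fold lower number from compound 2 to compound 4 (0.29 log units; within the scatter), so compound 2 and compound 4 cannot be told apart on potency. Going by these compounds alone, until now no two measured compounds differed in only one place, and this first clean comparison shows that the aromatic carbon para to a large group can carry a bromine atom, one extra heavy atom, without the number leaving the usual scatter of the measurement. No measurement bears on why the number holds at this position, so this result stands without an explanation.

A single step cannot show whether this tolerance is particular to bromo or extends to other groups on the same carbon, such as an amine, a carboxylic acid or a longer chain, any of which could move the number much further. It also leaves open whether the same change would behave alike on another ring of this series, such as the two-ring system of compound 1, which has no bromo partner among the compounds shown.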